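The source may hold more compounds than are shown below. What is called first, only, known or untested is meant among the compounds shown, and "the series" means these compounds.

In a functional assay on RKO cells (Homo sapiens) for inhibition, read by MTT assay, with a stated time of 48 h (a lower number here means a stronger inhibitor, a higher number a weaker inhibitor), two compounds that share a core have been measured so far. Compound 2 `COc1ccc(N(C)c2nc(C)nc3ccccc23)cc1[Se]C` holds the lower number of the pair at 11 nM, well ahead of compound 1 `COc1ccc(N(C)c2nc(C)nc3ccccc23)cc1OCCCCCC[Se]C#N` at 1540 nM.

The next structure is compound 3 `COc1ccc(N(C)c2nc(C)nc3ccccc23)cc1OCC[Se]C#N`, which differs from compound 2 at one place: a group of 6 heavy atoms (3 carbon, 1 nitrogen, 1 oxygen, 1 selenium; no ring) in place of a group of 2 heavy atoms (1 carbon, 1 selenium; no ring), on an aromatic carbon. The change sits on an aromatic carbon, ortho to a methoxy group. The group that enters ends in the same selenium and nitrile as the group of compound 1, but its chain is shorter.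

Among the compounds with values here, only one measured step bears on this: a 140-fold lower number from compound 1 to compound 2 (2.15 log units; beyond the scatter). This large step replaced a group of 10 heavy atoms with the small selenium group, and compound 3 partly reverses that swap. With a single step to go on, the size of the reversal is uncertain, but the number is expected to rise, probably without reaching the value of compound 1. The expected change is a 27-fold higher number from compound 2 to compound 3 (1.44 log units; beyond the scatter), which would be a rise beyond the scatter. For compound 3 the estimated value is 300 nM, with an expected range of 60 nM to 1500 nM.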

Compound 3, half-maximal inhibitory concentration: 27 nM
Estimate against measurement, compound 3: 11-fold (1.05 log units) above, and the stated range ends above it.
By their numbers in this assay, from the lowest: compound 2; then compound 3; then compound 1.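

Read in this assay, the step of a 57-fold lower number from compound 1 to compound 3 (1.76 log units; beyond the scatter) shows that, with the selenium and nitrile end kept in place, shortening the chain alone recovers most of the ground that compound 1 gave up. The step of a 2.5-fold higher number from compound 2 to compound 3 (0.39 log units; beyond the scatter) shows that this aromatic carbon, ortho to a methoxy group, can carry the larger oxygen-linked group at only a modest cost, though that cost is still beyond the scatter, so a large group here does not by itself mean a large loss. Nothing measured here explains why the chain length matters so much in these cells.

Compound 2 and compound 3 differ in the whole group at this position, so the oxygen link, the chain and the nitrile end cannot be separated, and a simple methoxy or ethoxy group at this carbon would help to divide the step among them. From the compounds shown here alone, it also remains open how the number moves for chains of intermediate length between those of compound 3 and compound 1, and whether an amine or a carboxylic acid at the chain end would serve as well as the selenium and nitrile end.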